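The source may hold more compounds than are shown below. What is called first, only, known or untested is meant among the compounds shown, and "the series" means these compounds.

Three compounds share one core and differ only in the group on the outer aromatic ring. Compound 1 `Cn1nc2c(=O)n(CC3(O)CCN(Cc4ccc(-c5ccco5)cc4Cl)CC3)cnc2c1-c1ccc(CNC=O)cc1` gives 20.9 nM in an assay on isolated protein for inhibition of ubiquitin carboxyl-terminal hydrolase 7 (Homo sapiens), with stated times of 30 min and 2 h; a higher number here means a weaker inhibitor, a lower number a stronger inhibitor. Compound 2 `CN(C)Cc1ccc(-c2c3ncn(CC4(O)CCN(Cc5ccc(-c6ccco6)cc5Cl)CC4)c(=O)c3nn2C)cc1` gives 131 nM, and compound 3 `Cn1nc2c(=O)n(CC3(O)CCN(Cc4ccc(-c5ccco5)cc4Cl)CC3)cnc2c1-c1ccc(C(F)(F)F)cc1` gives 530 nM, the highest of the three numbers. The next compound, compound 4 `Cn1nc2c(=O)n(CC3(O)CCN(Cc4ccc(-c5ccco5)cc4Cl)CC3)cnc2c1-c1ccc(C(=N)N)cc1`, carries a group of 3 heavy atoms (1 carbon, 2 nitrogen; no ring) in place of a group of 4 heavy atoms (1 carbon, 3 fluorine; no ring), on an aromatic carbon. For the measured compounds named here, two measured steps bear on this: a 25-fold higher number from compound 1 to compound 3 (1.40 log units; beyond the scatter) and a 4.0-fold higher number from compound 2 to compound 3 (0.61 log units; beyond the scatter) show that exchanging a nitrogen-bearing group for trifluoromethyl raised the number each time. Reversing that exchange in compound 4 is therefore expected to lower the number by a modest to large step, an 8.8-fold lower number from compound 3 to compound 4 (0.95 log units; beyond the scatter). Compound 4 is estimated at 60 nM, between 15 nM and 250 nM.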

Compound 4, half-maximal inhibitory concentration: 87.5 nM
Beside the measured number, compound 4's estimate is 1.5-fold (0.16 log units) below it; low and high end bracket the measured number.
By their numbers in this assay, from the lowest: compound 1; then compounds 4 and 2 (each within the scatter of the next); then compound 3.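

Putting the new group on this aromatic carbon in place of trifluoromethyl gives a 6.1-fold lower number from compound 3 to compound 4 (0.78 log units; beyond the scatter) and so shows that a third nitrogen-bearing group also improves on trifluoromethyl. Against the dimethylamino group, a 1.5-fold lower number from compound 2 to compound 4 (0.18 log units; within the scatter) leaves the two groups indistinguishable, whereas a 4.2-fold higher number from compound 1 to compound 4 (0.62 log units; beyond the scatter) shows that the (formylamino)methyl group of compound 1 stays ahead of the new group. No measurement shown explains these differences.

On these data alone, it remains open whether a plain aminomethyl group or a carboxylic acid here would match the (formylamino)methyl group. The effect of a longer chain carrying the formylamino group is also unknown.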